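Chloro for trifluoromethyl: cytotoxicity of compound 3 expected

The source may report more compounds than this note shows. Statements on the series, on what has been measured and on what is new or still open speak of the compounds shown alone.

Compound 1 `O=C1N(CCCCCCOc2ccc(Cl)cc2)CCN1c1cccnc1`: in a functional assay on cells (Homo sapiens) for cytotoxicity (a lower number here means that less compound is tolerated, a higher number that more compound is tolerated), compound 1 gives > 25000 nM, a limit of the assay.
Compound 2 `O=C1N(CCCCCCOc2ccc(C(F)(F)F)cc2)CCN1c1ccncn1`: in this assay compound 2 gives > 25000 nM, also a limit of the assay.

Compound 2 stands at the limit of > 25000 nM in this assay, at which 2 of the 2 values shown sit, so only a limit is known for it, and the same holds for compound 1. Compound 3 `O=C1N(CCCCCCOc2ccc(Cl)cc2)CCN1c1ccncn1` is not yet measured. It differs from compound 2 by chloro in place of trifluoromethyl on an aromatic carbon. Among the compounds with values here, no measured step shows what this change does here, so no shift beyond the scatter is expected; compound 3 is expected to sit at the limit as well, with an expected step that the limit leaves unreadable from compound 2 to compound 3. The estimate for compound 3 in this assay is 30000 nM, expected between 12000 nM and 100000 nM.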

Compound 3, half-maximal cytotoxic concentration: > 25000 nM
Compound 3 gave a limit, no number; the forecaster's own chance of this, stated with the estimate: 85%; the middle value is on the limit's open side.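

Neither step to compound 3, from compound 1 or from compound 2, can be read, since all three compounds stop at a limit: the limit of > 25000 nM in this assay, at which 3 of the 3 values shown sit.

On these data alone, how far chloro or pyrimidin-4-yl shifts the true values in this assay stays open.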